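Cyclohexyl in place of isopropyl in compound 2

The source may report more compounds than this note shows. Statements on the series, on what has been measured and on what is new or still open speak of the compounds shown alone.

Measured so far in a functional assay on MCF7 cells (Homo sapiens) for antiproliferative activity, read by MTT assay, with a stated time of 72 h; on this read-out higher numbers stand for weaker inhibition and lower numbers for stronger inhibition:
- Compound 1 `O=C1COc2ccc(-c3cnc(Cl)c(NS(=O)(=O)c4ccc(F)cc4)c3)cc2N1`: > 40000 nM (a limit of the assay, not a number)
- Compound 2 `CC(C)N1C(=O)COc2ccc(-c3cccc(NS(=O)(=O)c4ccc(F)cc4)c3)cc21`: 26000 nM
- Compound 3 `Cc1ccc(N2C(=O)COc3ccc(-c4cnc(Cl)c(NS(=O)(=O)c5ccc(F)cc5)c4)cc32)cc1`: 32600 nM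

Compound 2 gives 26000 nM in this assay, and this lies within the scatter of the value for compound 3. The two therefore cannot be ranked. Compound 1 stands only at a limit.

Compound 4 `O=C1COc2ccc(-c3cccc(NS(=O)(=O)c4ccc(F)cc4)c3)cc2N1C1CCCCC1` is the next compound to consider. It carries cyclohexyl in place of isopropyl on an amide-type nitrogen in a ring.

Going by the values given here, one measured step bears on this change, as it also falls on an amide-type nitrogen in a ring: an at least 1.2-fold lower number from compound 1 to compound 3 (0.08 log units; that floor lies within the scatter). There, 4-methylphenyl takes the place of hydrogen, on the core of compound 1 rather than that of compound 2. That step is only a floor, set by the limit of > 40000 nM in this assay, at which 1 of the 3 values shown sits, so it gives no size beyond the scatter and no direction.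

No step beyond the scatter is therefore expected, and the expected step is a 1.2-fold lower number from compound 2 to compound 4 (0.07 log units; within the scatter). For compound 4 the estimated value is 22000 nM, with an expected range from 9000 nM to 40000 nM.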

Compound 4, half-maximal inhibitory concentration: 21400 nM
Estimate against measurement, compound 4: 1.0-fold (0.01 log units) above; the measured number falls inside the stated range.
By their numbers in this assay, from the lowest: compounds 4, 2 and 3 (each within the scatter of the next). At a limit, above all of these: compound 1.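

Cyclohexyl in place of isopropyl on the amide-type nitrogen in a ring gives a 1.2-fold lower number from compound 2 to compound 4 (0.08 log units; within the scatter) in this assay. Going by these compounds alone, this is the first step at this position that can be read as a number at both ends, and it shows that, on the core of compound 2, the all-carbon ring and the extra carbon atoms leave the read-out within the scatter. The earlier step at this nitrogen, with 4-methylphenyl in place of hydrogen on the core of compound 1, gave only a floor: the limit of > 40000 nM in this assay, at which 1 of the 4 values shown sits.

The compounds shown leave open whether a group on this nitrogen that carries an amine or a carboxylic acid, or a longer chain, would bring a step beyond the scatter. As far as these compounds go, compound 1, with hydrogen on this nitrogen, stands at > 40000 nM, which is a limit of the assay and not a number, so what hydrogen gives on the core of compound 2 and what cyclohexyl gives on the core of compound 1 both remain open.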